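Amide extension on a quinolinone core: lipophilicity outlook

A few compounds are considered here, and "the series" means these few. Any claim that something is new, unique, unknown or untested is made for them only; others in the source may bear on it.

Measured so far:
compound 1, `CC(=O)Nc1ccc2c(C)cc(=O)[nH]c2c1`, 0.995 in a physicochemical assay for lipophilicity; on this read-out higher numbers stand for higher lipophilicity and lower numbers for lower lipophilicity
compound 2, `Cc1cc(O)nc2cc(N)ccc12`, 0.793
compound 3, `Cc1cc(=O)[nH]c2cc(NC(=O)c3c(Br)cccc3Br)ccc12`, 1.75

Compound 1 stands second highest of the three numbers in this assay. Its nearest neighbour is compound 2, whose value lies within the scatter of that of compound 1; compound 3 lies further away, beyond the scatter and higher.

Compound 4, `Cc1ccc(C(=O)Nc2ccc3c(C)cc(=O)[nH]c3c2)cc1`, is not yet measured. It differs from compound 1 in one place: 4-methylphenyl in place of methyl on a carbonyl carbon. Among the measured compounds shown here, no measured pair shows this exact step, so its size is not known from the numbers. An increase beyond the scatter is nevertheless expected, because compound 3 carries an amide with a six-membered aromatic ring of carbon only on the same carbonyl carbon and gives 1.75.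

For compound 4 a value of 2 is estimated, within 1.4 to 2.6, which means an expected step of a number 1.01 log units higher from compound 1 to compound 4 (beyond the scatter).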

Compound 4, partition coefficient: 1.67
The estimate for compound 4 lay 0.33 log units above the measured number, and the stated range covers the measured number.
By their numbers in this assay, from the lowest: compounds 2 and 1 (each within the scatter of the next); then compounds 4 and 3 (each within the scatter of the next).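

Putting 4-methylphenyl in place of methyl on a carbonyl carbon gives, in this assay, a number 0.68 log units higher from compound 1 to compound 4 (beyond the scatter). Among the compounds shown here, this pair gives the first direct reading of this change at this position, and the step is modest in size. Nothing available here accounts for the size of this step.

Still open, from the compounds shown here alone, is how phenyl without the methyl, a longer alkyl chain, or a phenyl ring carrying a carboxylic acid or an amine would compare on the same carbonyl carbon. Also open, going by these compounds, is whether the same change gives a similar step on a different core.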